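A few compounds are considered here, and "the series" means these few. Any claim that something is new, unique, unknown or untested is made for them only; others in the source may bear on it.

Three compounds in this series have been run in a functional assay on HT-29 cells (Homo sapiens) for antiproliferative activity, read by sulforhodamine B assay, with a stated time of 48 h; on this read-out higher numbers stand for weaker inhibition and lower numbers for stronger inhibition. Compound 1 `COc1ccc(NS(=O)(=O)c2ccc(N3CCNC3=O)cc2)cc1` gives 800 nM, compound 2 `O=C1NCCN1c1ccc(S(=O)(=O)Nc2ccc(I)cc2)cc1` gives 650 nM and compound 3 `COc1cccc(NS(=O)(=O)c2ccc(N3CCNC3=O)cc2)c1` gives 120 nM. Compound 3 stands lowest of the three: the step of a 6.7-fold lower number from compound 1 to compound 3 (0.82 log units; beyond the scatter) and the step of a 5.4-fold lower number from compound 2 to compound 3 (0.73 log units; beyond the scatter) both lie beyond the scatter, so compound 3 is the most potent measured so far. The step of a 1.2-fold lower number from compound 1 to compound 2 (0.09 log units; within the scatter) lies within the scatter, so compound 1 and compound 2 cannot be ordered.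

Compound 4 `Cc1cc(C)cc(NS(=O)(=O)c2ccc(N3CCNC3=O)cc2)c1` is the next entry. Its change from compound 3 is 3,5-dimethylphenyl in place of 3-methoxyphenyl on a sulfonamide nitrogen. Within the data shown here, no measured step exchanges a methoxy group for methyl groups, so nothing bears directly on this change. Among the measured compounds shown here, the step from compound 1 to compound 2 is the only one that swaps one substituent for another while keeping its place, and it stayed within the scatter. The two steps that moved a group, from compound 1 and from compound 2 to compound 3, were modest. On that basis a step of no more than modest size in this assay is expected from compound 3 to compound 4, with the direction open. Compound 4 is estimated at 160 nM, within 50 nM to 500 nM. This estimate means an expected step of a 1.3-fold higher number from compound 3 to compound 4 (0.12 log units; within the scatter).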

Compound 4, half-maximal inhibitory concentration: 82 nM
Compound 4: middle estimate off by 2.0-fold (0.29 log units), on the high side; the range from low to high includes it.
By their numbers in this assay, from the lowest: compounds 4 and 3 (each within the scatter of the next); then compounds 2 and 1 (each within the scatter of the next).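

In this assay, a 1.5-fold lower number from compound 3 to compound 4 (0.17 log units; within the scatter) stays within the scatter, so the 3,5-dimethylphenyl and 3-methoxyphenyl groups on the sulfonamide nitrogen cannot be ordered, and the oxygen of the methoxy group, with its hydrogen-bond acceptor, is not needed to reach this range of values. With a 7.9-fold lower number from compound 2 to compound 4 (0.90 log units; beyond the scatter) and a 9.8-fold lower number from compound 1 to compound 4 (0.99 log units; beyond the scatter) both beyond the scatter, a second group now stands apart from 4-iodophenyl and 4-methoxyphenyl, so among these four compounds, with none going against it, the two groups named with a substituent at the 3 position give lower numbers than the two named with one at the 4 position. No measured evidence on this change is available to account for these differences.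

Open, on these data alone, is whether an amine, a carboxylic acid or a longer chain in place of the methyl groups would keep the number in this range. Also open, as far as these compounds go, is how an unsubstituted phenyl group on the sulfonamide nitrogen would compare with the 3,5-dimethylphenyl and 3-methoxyphenyl groups.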